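This account rests on a few compounds, and the source may have more. Where it says the series, first, only, none or still open, it means among the compounds named here.

Compound 1 `Cc1ncc([N+](=O)[O-])n1CCSC(=S)N1CCC(Cc2ccccc2)CC1` and compound 2 `Cc1ncc([N+](=O)[O-])n1CCSC(=S)N1CCC(OC(=O)C(Cl)Cl)CC1` share one core and differ only at a saturated ring carbon. In an ADME assay on HeLa cells (Homo sapiens) for cytotoxicity (on this read-out lower numbers stand for stronger inhibition and higher numbers for weaker inhibition), compound 1 gives only a limit of the assay, > 1000 ug/mL. In this assay compound 2 also gives only a limit of the assay, > 1000 ug/mL. The step that the two limits leave unreadable from compound 1 to compound 2 therefore cannot be read, since both values sit at the limit of > 1000 ug/mL in this assay, at which 2 of the 2 values shown sit. Compound 3 `Cc1ncc([N+](=O)[O-])n1CCSC(=S)N1CCC(OC(=O)CSC(=S)N2CCCCC2)CC1` is the next compound to be measured in this assay and differs from compound 2 in that (a group of 10 heavy atoms (7 carbon, 1 nitrogen, 2 sulfur; one six-membered non-aromatic ring with 1 hetero atom) in place of a group of 3 heavy atoms (1 carbon, 2 chlorine; no ring), on a carbonyl carbon). Among the compounds with values here, no readable measured step bears on this change, so the only guide is that both measured compounds sit at the limit. For compound 3 a step of a number no higher from compound 2 to compound 3 (the limit leaves the size open) is expected, which is to say no change beyond the scatter and most likely again a limit. The estimate for compound 3 is 1000 ug/mL, in a range from 300 ug/mL to 3000 ug/mL.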

Compound 3, half-maximal inhibitory concentration: 980 ug/mL
Beside the measured number, compound 3's estimate is 1.0-fold (0.01 log units) above it; the range from low to high includes it.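

In this assay, putting the ring-bearing group of 10 heavy atoms in place of dichloromethyl on the carbonyl carbon gives an at least 1.0-fold lower number from compound 2 to compound 3 (0.00 log units; that floor lies within the scatter). So even this much larger group, with its six-membered non-aromatic ring and two sulfur atoms, brings no change that can be told from the scatter, although compound 3 supplies the first true number of the set. The step between the other two compounds still cannot be read, and the only firm reference remains the shared limit of the assay: the limit of > 1000 ug/mL in this assay, at which 2 of the 3 values shown sit.

Going by these compounds, how far the values of the two limit compounds actually lie from that of compound 3 stays unknown. Also open, on these data alone, is whether a different group on this carbonyl carbon, such as a primary amine, a carboxylic acid or a longer alkyl chain, would give a clearly stronger effect on these cells.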